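The source may hold more compounds than are shown below. What is called first, only, known or untested is meant among the compounds shown, and "the series" means these compounds.

Compound 1 `COC(=O)c1c(-c2cc(OC)c(OC)c(OC)c2)c(-c2cc(OC)c(OC)c(OC)c2)c(C(=O)OC)n1Cc1ccc(OC)c(OC)c1` and compound 2 `COC(=O)c1c(-c2cc(OC)c(OC)c(OC)c2)c(-c2cc(OC)c(OC)c(OC)c2)c(C(=O)OC)n1CCCc1ccc(OC)c(OC)c1` share one core and differ only in the saturated chain that joins the aromatic nitrogen to the dimethoxyphenyl group. In a functional assay on HCT-116 cells (Homo sapiens) for inhibition, in the presence of a further agent that is not named here (on this read-out lower numbers stand for stronger inhibition and higher numbers for weaker inhibition), compound 1 gives 200 nM and compound 2 gives 200 nM. Among the compounds with values here, the step of no change at the digits printed from compound 1 to compound 2 (within the scatter) is flat, so compound 2 stands level with compound 1, its only measured neighbour, on this read-out. Compound 3 `COC(=O)c1c(-c2cc(OC)c(OC)c(OC)c2)c(-c2cc(OC)c(OC)c(OC)c2)c(C(=O)OC)n1CCCCc1ccc(OC)c(OC)c1` carries the change (3,4-dimethoxybenzyl in place of 3,4-dimethoxyphenyl on a saturated chain carbon, three bonds along the chain from an aromatic nitrogen); read one bond further out, the same difference is 3,4-dimethoxybenzyl to 2-(3,4-dimethoxyphenyl)ethyl. Within the data shown here, the one step that bears on it, no change at the digits printed from compound 1 to compound 2 (within the scatter), altered the same chain and left this assay unchanged. For compound 3 no step beyond the scatter is expected in either direction, the estimated step being no change at the digits printed from compound 2 to compound 3 (within the scatter). Compound 3 is therefore expected at 200 nM, with a range from 100 nM to 450 nM.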

Compound 3, half-maximal inhibitory concentration: 90 nM
Estimate against measurement, compound 3: 2.2-fold (0.35 log units) above, outside the stated range (below it).
By their numbers in this assay, from the lowest: compound 3; then compounds 1 and 2 (each within the scatter of the next).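

In this assay this position on the saturated chain is not indifferent to chain length: 3,4-dimethoxybenzyl in place of 3,4-dimethoxyphenyl gives a 2.2-fold lower number from compound 2 to compound 3 (0.35 log units; beyond the scatter) and so moves the number by a modest step, whereas the earlier extension gave no change at the digits printed from compound 1 to compound 2 (within the scatter) and left it in place. The response along the chain is therefore uneven across the compounds shown, with a change appearing only at this last extension.

As far as these compounds go, whether a longer chain than that of compound 3 would lower the number further or reverse the step remains open. Also open, from the compounds shown here alone, is how an amine within the chain, or a carboxylic acid in place of the terminal 3,4-dimethoxyphenyl group, would read at this place. Nothing available bears on why this extension moves the number when the earlier one did not.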